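This account rests on a few compounds, and the source may have more. Where it says the series, first, only, none or still open, it means among the compounds named here.

Series notes. For the measured compounds named here, the shared core of compound 1 `O=C(/C=C\c1ccccc1F)N1N=C(c2ccncc2)OC1c1c[nH]c2ccccc12` carries a double-bonded chain that ends in a substituted phenyl, and this phenyl is the only place that changes across the set. In an ADME assay on HeLa cells (Homo sapiens) for cytotoxicity, read by MTT assay, with a stated time of 72 h (a higher number here means a weaker inhibitor of growth, a lower number a stronger inhibitor of growth), compound 1 gives > 30 ug/mL, which is a limit of the assay and not a number. Compound 2 `O=C(/C=C\c1cccc(F)c1)N1N=C(c2ccncc2)OC1c1c[nH]c2ccccc12` carries the 3-fluorophenyl instead. In this assay compound 2 gives > 30 ug/mL, again a limit. Going by the values given here, compound 3 `O=C(/C=C\c1ccc(Cl)cc1Cl)N1N=C(c2ccncc2)OC1c1c[nH]c2ccccc12` carries the 2,4-dichlorophenyl and is the one member with a number: in this assay compound 3 gives 29.3 ug/mL, so it stands as the only read value among the three. The steps are a step that the two limits leave unreadable from compound 1 to compound 2, an at least 1.0-fold lower number from compound 1 to compound 3 (0.01 log units; that floor lies within the scatter) and an at least 1.0-fold lower number from compound 2 to compound 3 (0.01 log units; that floor lies within the scatter); all three are shaped by the limit of > 30 ug/mL in this assay, at which 2 of the 3 values shown sit.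

Compound 4 `O=C(/C=C\c1cccc(Br)c1)N1N=C(c2ccncc2)OC1c1c[nH]c2ccccc12` is the next member. The change from compound 3 is 3-bromophenyl in place of 2,4-dichlorophenyl on a double-bonded chain carbon bound to a double-bonded chain carbon. Among the compounds with values here, the steps that bear on it, from compound 1 and compound 2 to compound 3, are both floors inside the scatter, so no step beyond the scatter is expected in this assay, in either direction, and a further limit is the likelier outcome. Compound 4 is therefore estimated at 30 ug/mL, a step of a 1.0-fold higher number from compound 3 to compound 4 (0.01 log units; within the scatter), with a range from 12 ug/mL to 80 ug/mL.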

Compound 4, concentration for 50% growth inhibition: > 30 ug/mL
Compound 4: only a limit was reported (the forecaster's own chance of this, stated with the estimate: 60%); the middle value lies on the limit itself.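

In this assay, for the compounds shown here, 3-bromophenyl in place of 2,4-dichlorophenyl gives an at least 1.0-fold higher number from compound 3 to compound 4 (0.01 log units; that floor lies within the scatter), so this floor does not separate the only compound with a read value from the new bromo member. The steps from compound 1 and compound 2 to compound 4, including bromo in place of fluoro on an aromatic carbon, cannot be read, since both ends of each are limits; a change of halogen on this phenyl therefore gives no measurable difference here, and neither fluoro nor bromo yields a read value. What can be learned about this position from the halogenated phenyls shown is now bounded by a single ceiling: the limit of > 30 ug/mL in this assay, at which 3 of the 4 values shown sit.

Open, as far as these compounds go, is whether a phenyl carrying a group of another kind at this position, such as an amine, a carboxylic acid or a methoxy group, would give a read value clearly apart from that of compound 3 in this assay. Also open, from the compounds shown here alone, is whether any real difference exists among compound 1, compound 2 and compound 4, which could be settled only by values read on a scale extending past the ceiling.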